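The source may report more compounds than this note shows. Statements on the series, on what has been measured and on what is new or still open speak of the compounds shown alone.

Compound 1 `C=C(C(=O)Nc1ccccc1)C(F)(F)F` is a small amide with a trifluoromethyl group on its unsaturated chain. In an ADME assay for pharmacokinetics, read by LC-MS, in phosphate buffer, with a stated time of 120 min, at pH 7.4, tested at 1 uM, in the presence of a further agent that is not named here (on this read-out lower numbers stand for a shorter-lived compound and higher numbers for a longer-lived compound), compound 1 gives 0.25 h. A second compound, compound 2 `O=C(/C=C/CN1CCCCC1)Nc1ccccc1`, is measured in the same way, and in this assay compound 2 gives 2.95 h. Of these two numbers, compound 1 stands at the lowest, and the gap up to compound 2 lies beyond the usual scatter, so compound 1 is the shorter-lived of the pair.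

Compound 3 `C=C(CO)C(=O)Nc1ccccc1` has not yet been measured. It differs from compound 1 in one place: hydroxymethyl in place of trifluoromethyl on a double-bonded chain carbon bound to a carbonyl carbon. Among the compounds with values here, no two measured compounds differ in only one place, so no measured step of a comparable kind is available as a guide; the only footing is that compound 1 sits at the short-lived end of the two numbers. The step of a 10-fold higher number from compound 1 to compound 3 (1.00 log units; beyond the scatter) is expected to raise the number, by an amount beyond the scatter. For compound 3 the estimate in this assay is 2.5 h, expected to fall between 0.8 h and 8 h.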

Compound 3, half-life: > 8.53 h
Compound 3 gave a limit, no number; the forecaster's own chance of this, stated with the estimate: 10%; at least 3.4-fold (0.53 log units) between middle value and limit.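

Replacing trifluoromethyl with hydroxymethyl on a double-bonded chain carbon bound to a carbonyl carbon gives, in this assay, an at least 34-fold higher number from compound 1 to compound 3 (1.53 log units; beyond the scatter). Within the data shown here, the value for compound 3 is a limit of the assay and not a number, so this step gives only the smallest size the change can have: the limit of > 8.53 h in this assay, at which 1 of the 3 values shown sits. The earlier compounds included no pair differing in one place, so this is the first direct reading that a change at this place alone, with the rest of the core kept, can shift the half-life by an amount beyond the scatter.

A single pair cannot tell whether the result depends on the loss of trifluoromethyl, on the arrival of hydroxymethyl, or on both. Other groups at the same place, such as a plain methyl, a methoxymethyl or an aminomethyl, would be needed to separate these readings, and the true half-life of compound 3 also remains open, with only its limit in hand.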